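Nitro to chloro on compound 3: working notes

The source may hold more compounds than are shown below. What is called first, only, known or untested is meant among the compounds shown, and "the series" means these compounds.

- compound 1 `CNC(=O)c1cc(Oc2ccc(C3=NNC(c4ccc(F)cc4Cl)C3)cc2)ccn1`: 11500 nM
- compound 2 `CNC(=O)c1cc(Oc2ccc(C3=NNC(c4ccc([N+](=O)[O-])cc4)C3)cc2)ccn1`: > 50000 nM (a limit of the assay)
- compound 3 `CNC(=O)c1cc(Oc2ccc(C3CC(c4ccc([N+](=O)[O-])cc4)=NN3)cc2)ccn1`: 28900 nM

In a functional assay on HepG2 cells (Homo sapiens) for cytotoxicity, read by MTT assay, with a stated time of 72 h (on this read-out lower numbers stand for stronger inhibition and higher numbers for weaker inhibition), compound 3 gives 28900 nM, the higher of the two true numbers, and compound 1 lies lower at 11500 nM, a gap beyond the scatter. Compound 2 sits at the limit of > 50000 nM in this assay, at which 1 of the 3 values shown sits.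

Compound 4 `CNC(=O)c1cc(Oc2ccc(C3CC(c4ccc(Cl)cc4)=NN3)cc2)ccn1` carries chloro in place of nitro on an aromatic carbon, para to a large group: chloro in place of nitro on an aromatic carbon. The same difference reads 4-nitrophenyl to 4-chlorophenyl.

Among the compounds with values here, one measured step bears on this: an at least 4.3-fold higher number from compound 1 to compound 2 (0.63 log units; beyond the scatter), with 4-nitrophenyl in place of 2-chloro-4-fluorophenyl on a saturated ring carbon. Its size is open-ended, since it ends at a limit. Within the data shown here, it transfers only loosely, as 2-chloro-4-fluorophenyl is not 4-chlorophenyl and only one such pair has been measured. Read in reverse, it points to a lower number in this assay on leaving nitro for halogen, so a modest step in that direction is expected. The expected change is a 2.2-fold lower number from compound 3 to compound 4 (0.35 log units; beyond the scatter). For compound 4 the estimated value is 13000 nM, with an expected range of 5000 nM to 38000 nM.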

Compound 4, half-maximal inhibitory concentration: 10900 nM
Compound 4: middle estimate off by 1.2-fold (0.08 log units), on the high side, within the range that was stated.
By their numbers in this assay, from the lowest: compounds 4 and 1 (each within the scatter of the next); then compound 3. At a limit, above all of these: compound 2.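

In this assay, chloro in place of nitro on an aromatic carbon, para to a large group, gives a 2.7-fold lower number from compound 3 to compound 4 (0.42 log units; beyond the scatter). This is the only step shown that has a closed size and a single change of one group, and it runs the same way as the open-ended an at least 4.3-fold higher number from compound 1 to compound 2 (0.63 log units; beyond the scatter), where the nitro compound again carries the higher number, although that step involves a different group on a saturated ring carbon. The value for compound 2 is a limit, so only the direction of that earlier step can be set beside the new one: the limit of > 50000 nM in this assay, at which 1 of the 4 values shown sits.

Still open, on these data alone, is whether the lower number belongs to chloro itself or simply goes with the loss of nitro, and an amine or a methoxy group at this place would separate those two readings. Also open, as far as these compounds go, is how far this one step carries to the arrangement of compound 2, and the data give no cause for the step in either case.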